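The source may hold more compounds than are shown below. What is called first, only, known or untested is meant among the compounds shown, and "the series" means these compounds.

Measured compounds:
- Compound 1, `C=CCn1c(=O)/c(=C\c2cccc(C)c2)[nH]c(=O)/c1=C\c1ccccc1OC`, gives 22700 nM in a functional assay on A549 cells (Homo sapiens) for cytotoxicity, read by CCK-8 assay, with a stated time of 72 h; a higher number here means a weaker inhibitor, a lower number a stronger inhibitor.
- Compound 2, `C=CCn1c(=O)/c(=C\c2ccccc2F)[nH]c(=O)/c1=C\c1ccccc1OC`, is reported as "not active" (no number reported) in this assay.
- Compound 3, `C=CCn1c(=O)/c(=C\c2cccc(Cl)c2)[nH]c(=O)/c1=C\c1ccccc1OC`, gives 5200 nM in this assay.

Compound 3 therefore holds the lowest of the two numbers shown, with compound 1 being the nearest; the one measured step, a 4.4-fold lower number from compound 1 to compound 3 (0.64 log units; beyond the scatter), is modest but beyond the scatter. Compound 4, `C=CCn1c(=O)/c(=C\c2cc(Br)ccc2F)[nH]c(=O)/c1=C\c1ccccc1OC`, differs from compound 3 by 5-bromo-2-fluorophenyl in place of 3-chlorophenyl on a double-bonded chain carbon bound to an aromatic carbon. Within the data shown here, no measured step covers this change directly. Compound 2, which also carries a fluorine on the aromatic ring, was reported as not active, and the halogen in compound 3 went with a lower number than compound 1. Weighing these, a step of a 1.7-fold higher number from compound 3 to compound 4 (0.24 log units; within the scatter) is expected, toward a somewhat higher number. Compound 4 is estimated at 9000 nM, within 2500 nM to 35000 nM.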

Compound 4, half-maximal inhibitory concentration: "not active" (no number reported)
Nothing numeric was reported for compound 4, so the estimate cannot be set against anything.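

Among these compounds, compound 4 was reported as not active, with no number, so no step from compound 3 to compound 4 can be read, and no evidence bears on this result. The compounds shown leave open whether the 5-bromo-2-fluorophenyl group itself accounts for that outcome.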